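From fluoro to methoxy in a mast cell assay

This account rests on a few compounds, and the source may have more. Where it says the series, first, only, none or still open, it means among the compounds named here.

- compound 1 `CC1CC/C(=N\Nc2ccc(F)cc2)c2ncc(C(=O)O)c(=O)n21` gives 1200 nM so far
- compound 2 `C[C@H]1CC/C(=N\Nc2ccc(O)cc2)c2ncc(C(=O)O)c(=O)n21` gives 26200 nM so far

In a functional assay (mast cells) for inhibition, with Rattus norvegicus as the target (a lower number here means that less compound is needed, a higher number that more compound is needed for the effect), compound 1 holds the lower of the two numbers, and its gap to compound 2 is beyond the usual scatter. The next candidate, compound 3 `COc1ccc(N/N=C2\CCC(C)n3c2ncc(C(=O)O)c3=O)cc1`, has not been measured yet. It keeps the core of compound 1 and changes one group: methoxy in place of fluoro on an aromatic carbon with everything else the same.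

For the measured compounds named here, no two measured compounds differ in one place only, so nothing shows directly what this swap does. Compound 1 at 1200 nM is the lowest number available and compound 2 at 26200 nM lies well higher, so a modest rise in this assay seems likelier than a fall. The expected change is a 2.5-fold higher number from compound 1 to compound 3 (0.40 log units; beyond the scatter) in this estimate. For compound 3 the estimated value is 3000 nM with an expected range from 900 nM to 12000 nM for now.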

Compound 3, half-maximal effective concentration: 128000 nM
The estimate for compound 3 lay 43-fold (1.63 log units) below the measured number, and the stated range ends below it.
By their numbers in this assay, from the lowest: compound 1; then compound 2; then compound 3.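

In this assay, putting methoxy in place of fluoro on an aromatic carbon, para to a large group, gives a 110-fold higher number from compound 1 to compound 3 (2.03 log units; beyond the scatter). For the compounds shown here, this is the first direct reading of a single change in this set, as compound 1 and compound 2 differ in more than one place, and it shows that the number is highly sensitive to which group sits at this position. The data at hand offer no measurement that accounts for the size of this step.

The compounds shown leave open how a hydrogen, a chlorine or an amine at this position would compare with fluoro, and whether an ethoxy group, with its longer chain, would push the number further than methoxy. A single step also cannot say whether this swap would have a similar effect on a different core.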